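The source may hold more compounds than are shown below. What is called first, only, known or untested is meant among the compounds shown, and "the series" means these compounds.

Working notes on the series. Compound 1 `COc1ccccc1-n1nncc1CN1C(=O)C2(C(C#N)=C(N)Oc3c2c2nc4ccccc4nc2c2ccccc32)c2ccccc21` and compound 2 `CCOc1ccc(-n2nncc2CN2C(=O)C3(C(C#N)=C(N)Oc4c3c3nc5ccccc5nc3c3ccccc43)c3ccccc32)cc1` share the core with a substituted phenyl on the aromatic nitrogen of the triazole ring; compound 3 `CC(=O)Nc1ccc(-n2nncc2CN2C(=O)C3(C(C#N)=C(N)Oc4c(N)cc5nc6ccccc6nc5c43)c3ccccc32)cc1` carries an amino group on the core and a 4-acetamidophenyl at that nitrogen. In a functional assay on HCT-116 cells (Homo sapiens) for antiproliferative activity, read by MTT assay, with a stated time of 48 h (a higher number here means a weaker inhibitor, a lower number a stronger inhibitor), compound 1 gives only a limit, > 50000 nM. In this assay compound 2 likewise gives only a limit, > 50000 nM. In this assay compound 3 also gives only a limit, > 50000 nM.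

Going by the values given here, the one step between measured compounds that differ in a single place, a step that the two limits leave unreadable from compound 1 to compound 2, cannot be read, since both ends are limits. The evidence across the set is summed up by the limit of > 50000 nM in this assay, at which 3 of the 3 values shown sit: no number has yet been obtained for any compound. Compound 3 therefore stands at the limit, with no measured neighbour to set a direction.

Compound 4 `CCc1cccc(CC)c1-n1nncc1CN1C(=O)C2(C(C#N)=C(N)Oc3c(N)cc4nc5ccccc5nc4c32)c2ccccc21` differs from compound 3 by 2,6-diethylphenyl in place of 4-acetamidophenyl on an aromatic nitrogen. Among the compounds with values here, no measured step bears on this change, and the only step in hand is unreadable. The step is expected to be a number no higher from compound 3 to compound 4 (the limit leaves the size open), with no measured ground for a shift beyond the scatter. Compound 4 is estimated at 50000 nM, within 15000 nM to 100000 nM.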

Compound 4, half-maximal inhibitory concentration: 37600 nM
Compound 4: the middle estimate sits 1.3-fold (0.12 log units) above what was measured, within the range that was stated.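

With 2,6-diethylphenyl in place of 4-acetamidophenyl on an aromatic nitrogen, this assay gives an at least 1.3-fold lower number from compound 3 to compound 4 (0.12 log units; that floor lies within the scatter). Going by these compounds alone, this is the first step with a direction, and it shows that a number can be obtained at this position with an all-carbon group of the same heavy-atom count, without the hydrogen-bond donor and acceptor of 4-acetamidophenyl. Compound 4 remains the only compound here with a number, and the rest of the set stays at the limit: the limit of > 50000 nM in this assay, at which 3 of the 4 values shown sit.

From the compounds shown here alone, the true size of this step remains open, and so does whether it exceeds the scatter, as only its floor can be read. Also open, going by these compounds, is how a longer chain in place of the ethyl groups, or an amine or a carboxylic acid on the phenyl ring, would read in this assay.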